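Working notes: from compound 1 to compound 4

This account rests on a few compounds, and the source may have more. Where it says the series, first, only, none or still open, it means among the compounds named here.

In a functional assay on MIA PaCa-2 cells (Homo sapiens) for inhibition, read by MTT assay, with a stated time of 72 h, tested at 50 uM (a higher number here means more inhibition of growth at the concentration tested, a lower number less inhibition of growth), compound 1 (`C=CCc1ccc(OCc2cn(-c3ccccc3CO)nn2)c(O)c1`) gives 52.1%, second highest of three values. Compound 2 (`C=CCc1cc(O)c(O)c(CN2CCC(CO)CC2)c1`) gives 38.6%, and compound 3 (`C=CCc1cc(O)c(O)c(CN2CCC(Cc3ccccc3)CC2)c1`) gives 90.9%; both lie beyond the scatter from compound 1. Compound 4 (`C=CCc1ccc(OCc2cn(-c3ccc(Br)cc3)nn2)c(O)c1`) carries 4-bromophenyl in place of 2-(hydroxymethyl)phenyl on an aromatic nitrogen. Within the data shown here, no measured step covers this change directly. The nearest guide is the large step of a number 52.3 percentage points higher from compound 2 to compound 3 (beyond the scatter), where phenyl replaces hydroxy at a different place on a different core, so it bears only loosely. A smaller rise is therefore expected, estimated as a number 12.9 percentage points higher from compound 1 to compound 4 (beyond the scatter). For compound 4 the expected value is 65%, with an estimated range from 42% to 88%.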

Compound 4, percent growth inhibition at one concentration: 47.3%
The estimate for compound 4 lay 17.7 percentage points above the measured number; the measured number falls inside the stated range.
By their numbers in this assay, from the lowest: compounds 2, 4 and 1 (each within the scatter of the next, the first and the last beyond it); then compound 3.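

In this assay, 4-bromophenyl in place of 2-(hydroxymethyl)phenyl on an aromatic nitrogen gives a number 4.8 percentage points lower from compound 1 to compound 4 (within the scatter). At this position, the first change shown here, the hydrogen-bond donor and acceptor counted in the leaving group are gone and the read-out stays within the scatter. No measurement on hand accounts for this result.

As far as these compounds go, the hydroxymethyl group and the bromine change together, so their separate contributions remain open. Also open, from the compounds shown here alone, is how an amine, a carboxylic acid or a longer chain on the phenyl ring would read in this assay.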